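Methoxy in place of chloro on the aromatic carbon

The source may report more compounds than this note shows. Statements on the series, on what has been measured and on what is new or still open speak of the compounds shown alone.

Values in an ADME assay on Vero cells (Chlorocebus sabaeus) for cytotoxicity, read by neutral red uptake; a lower number here means a stronger inhibitor, a higher number a weaker inhibitor:
- Compound 1 `COC(/C=C/c1ccc(O)cc1)=C1\C(=O)C=C(C)C1=O`: 3.7 ug/mL
- Compound 2 `CC1=CC(=O)/C(=C(O)/C=C/c2ccc(Cl)cc2)C1=O`: > 10 ug/mL
- Compound 3 `COC(/C=C/c1ccc(Cl)cc1)=C1\C(=O)C=C(C)C1=O`: 5.5 ug/mL

Compound 3 gives 5.5 ug/mL and compound 1 gives 3.7 ug/mL, two numbers within the usual scatter of each other. Compound 2 gives > 10 ug/mL, which is a limit of the assay and not a number.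

The next compound, compound 4 `COC(/C=C/c1ccc(OC)cc1)=C1\C(=O)C=C(C)C1=O`, differs from compound 3 in one group: methoxy in place of chloro on an aromatic carbon. This puts methoxy in place of chloro on an aromatic carbon, para to a large group.

The nearest guide is a swap on that same aromatic carbon, chloro in place of hydroxy: a 1.5-fold higher number from compound 1 to compound 3 (0.17 log units; within the scatter). The other measured step, an at least 1.8-fold lower number from compound 2 to compound 3 (0.25 log units; that floor lies within the scatter), puts methyl in place of hydrogen on a different oxygen, so it bears on this change only loosely.

No step beyond the scatter is therefore expected in this assay, and the estimated step is a 1.1-fold lower number from compound 3 to compound 4 (0.04 log units; within the scatter). Compound 4 is expected at 5 ug/mL, with an estimated range of 2.5 ug/mL to 10 ug/mL.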

Compound 4, half-maximal inhibitory concentration: 5 ug/mL
Beside the measured number, compound 4's estimate shows no gap at the digits printed; low and high end bracket the measured number.
By their numbers in this assay, from the lowest: compounds 1, 4 and 3 (each within the scatter of the next). At a limit, above all of these: compound 2.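

In this assay, the aromatic carbon para to a large group has now carried hydroxy, chloro and methoxy on the shared core, and chloro giving way to methoxy produces a 1.1-fold lower number from compound 3 to compound 4 (0.04 log units; within the scatter). Methyl in place of hydrogen on the oxygen of the hydroxy group gives a 1.4-fold higher number from compound 1 to compound 4 (0.13 log units; within the scatter), so none of these three groups stands apart from the others in this assay. That same methyl change can now be read at two different oxygens, although the comparison stays incomplete: the same change on two cores in this assay, an at least 1.8-fold lower number (0.25 log units; that floor lies within the scatter) from compound 2 to compound 3 and a 1.4-fold higher number (0.13 log units; within the scatter) from compound 1 to compound 4; the limit leaves it open whether they differ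

On these data alone, whether an amine or a carboxylic acid on this aromatic carbon would move the number beyond the scatter remains open. As far as these compounds go, it is also open whether a longer chain in place of the methyl of the methoxy group would do so.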